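This account rests on a few compounds, and the source may have more. Where it says the series, first, only, none or still open, it means among the compounds named here.

Working notes on the series. In an assay on membranes from HeLa cells for displacement of a labelled ligand from adenosine receptor A3 (Homo sapiens), read by scintillation counting, with a stated time of 180 min, tested at 1 uM (on this read-out lower numbers stand for less inhibition and higher numbers for more inhibition at the one concentration tested (going by the name of the read-out)), compound 2 `CC1=C(C(=O)NC(C)C)C(c2ccco2)NC(=O)N1` gives 4%. Compound 3 `CC1=C(C(=O)NC(C)C)C(c2ccoc2)NC(=O)N1` gives 3% and compound 1 `CCCC(=O)C1=C(C)NC(=O)NC1c1ccco1` gives 1%, so all three numbers lie within the scatter of one another. The exchange of isopropylamino in place of propyl on a carbonyl carbon gave a number 3 percentage points higher from compound 1 to compound 2 (within the scatter), and furan-3-yl in place of furan-2-yl on a saturated ring carbon gave a number 1 percentage points lower from compound 2 to compound 3 (within the scatter). Compound 4 `CC1=C(c2ncc(C)o2)C(c2ccco2)NC(=O)N1` differs from compound 2 by 5-methyl-1,3-oxazol-2-yl in place of isopropylcarbamoyl on a double-bonded ring carbon. Going by the values given here, no measured step removes the whole isopropylcarbamoyl group; the only step touching that carbonyl carbon stayed within the scatter, so no change beyond the scatter is expected here. Compound 4 is therefore estimated at 5%, range 0% to 18%, an expected a number 1 percentage points higher from compound 2 to compound 4 (within the scatter).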

Compound 4, a percentage reported as inhibition, at one concentration (the size of the read-out at that concentration, not a potency): 4%
Compound 4: the middle estimate sits 1 percentage points above what was measured; low and high end bracket the measured number.
By their numbers in this assay, from the lowest: compounds 1, 3, 2 and 4 (each within the scatter of the next).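

In this assay, going by these compounds alone, the whole carbonyl-bearing group on the double-bonded ring carbon was replaced for the first time: 5-methyl-1,3-oxazol-2-yl in place of isopropylcarbamoyl gave no change at the digits printed from compound 2 to compound 4 (within the scatter), and in place of propylcarbonyl it gave a number 3 percentage points higher from compound 1 to compound 4 (within the scatter). Neither the carbonyl nor the amide hydrogen is therefore needed to keep the number where it stands, and a five-membered aromatic ring fits this position without a step beyond the scatter. No evidence bearing on this result is available.

From the compounds shown here alone, all four numbers lie within the scatter, so it remains open whether any group at this carbon can move the read-out. An amine, a carboxylic acid or a longer chain at this position would test that.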